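The source may report more compounds than this note shows. Statements on the series, on what has been measured and on what is new or still open speak of the compounds shown alone.

Of the compounds shown here, three of a shared core have been measured in a functional assay on MDA-MB-231 cells (Homo sapiens) for cytotoxicity, read by MTT assay, with a stated time of 72 h; on this read-out higher numbers stand for weaker inhibition and lower numbers for stronger inhibition. Compound 1 `CN(C)Cc1ccc2nc(NC(=O)N/N=C/c3cn(Cc4ccccc4)c4ccccc34)sc2c1` gives 1340 nM and stands lowest of the three numbers, though not beyond the scatter of the other two. Going by the values given here, compound 2 `CCN(CC)Cc1ccc2nc(NC(=O)N/N=C/c3cn(Cc4ccccc4)c4ccccc34)sc2c1` gives 1470 nM, and the single step of a 1.1-fold higher number from compound 1 to compound 2 (0.04 log units; within the scatter) shows that swapping one amine for another on the saturated chain carbon leaves the read-out essentially unchanged. Compound 3 `CC1CCN(Cc2ccc3nc(NC(=O)N/N=C/c4c[nH]c5ccccc45)sc3c2)CC1` gives 2460 nM; it differs from compound 1 in two places at once, so its number can only be set beside that of compound 1 without a step.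

Compound 4 `CN(C)Cc1ccc2nc(NC(=O)N/N=C/c3cn(Cc4ccc(Cl)cc4)c4ccccc34)sc2c1` is not yet measured in this assay. It differs from compound 1 by chloro in place of hydrogen on an aromatic carbon. Among the compounds with values here, no measured step touches this part of the molecule: the only step in hand lies at the amine on the other end of the core and was within the scatter, and nothing has been measured at the benzyl group. Compound 4 is therefore expected to sit close to compound 1, with a step of a 1.2-fold lower number from compound 1 to compound 4 (0.09 log units; within the scatter) that is not expected to clear the scatter. The estimate for compound 4 is 1100 nM, within the range 450 nM to 2700 nM.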

Compound 4, half-maximal inhibitory concentration: 880 nM
The estimate for compound 4 lay 1.3-fold (0.10 log units) above the measured number; measured number inside the range.
By their numbers in this assay, from the lowest: compounds 4, 1, 2 and 3 (each within the scatter of the next, the first and the last beyond it).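

In this assay, going by these compounds alone, the change from benzyl to 4-chlorobenzyl gives a 1.5-fold lower number from compound 1 to compound 4 (0.18 log units; within the scatter), the first reading at this end of the molecule, since the only earlier step lay at the amine at the other end of the core. The chloro, placed para to a large group on the six-membered aromatic ring, therefore leaves the number inside the usual scatter, just as the amine swap did with a 1.1-fold higher number from compound 1 to compound 2 (0.04 log units; within the scatter), so neither of the two single changes in hand separates its pair of compounds. No measurement bears on why the number stays in this range, so the result carries no explanation.

The compounds shown leave open whether a larger or different group at the same place, such as methoxy, trifluoromethyl, a carboxylic acid or a second phenyl ring, would carry the number beyond the scatter, and whether a chloro elsewhere on that ring would read as this one does. They also leave open whether the 4-chlorobenzyl group would read the same alongside the diethylamino group of compound 2 or alongside a morpholine at the amine end.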